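The compounds below may be only part of what the source reports. "The series", "measured", "known", "first", "only" and "open" are said of these compounds alone.

Three compounds have been measured in a functional assay on HT-29 cells (Homo sapiens) for inhibition, read by MTT assay, with a stated time of 72 h; on this read-out lower numbers stand for stronger inhibition of growth and higher numbers for weaker inhibition of growth:

Compound 1 `O=S(=O)(NCCCNCC1COc2ccccc2O1)c1cc(C(F)(F)F)cc(C(F)(F)F)c1` gives 2200 nM.
Compound 2 `O=S(=O)(NCCCNCc1ccc(C(F)(F)F)cc1)c1cc(C(F)(F)F)cc(C(F)(F)F)c1` gives 2900 nM.
Compound 3 `O=S(=O)(NCCCNCc1cccc2ccccc12)c1cc(C(F)(F)F)cc(C(F)(F)F)c1` gives 2600 nM.

On these numbers compound 3 stands second highest of three, with compound 2 as its nearest neighbour and compound 1 as its furthest, and both of those separations lie within the scatter of this assay . The three compounds share one core and differ only in the group carried on a saturated chain carbon bound to an amine nitrogen. The steps among them are a 1.3-fold higher number from compound 1 to compound 2 (0.12 log units; within the scatter), a 1.2-fold higher number from compound 1 to compound 3 (0.07 log units; within the scatter) and a 1.1-fold lower number from compound 2 to compound 3 (0.05 log units; within the scatter), each within the scatter.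

Compound 4 `COc1ccccc1CNCCCNS(=O)(=O)c1cc(C(F)(F)F)cc(C(F)(F)F)c1` carries the change (2-methoxyphenyl in place of naphthalen-1-yl on a saturated chain carbon bound to an amine nitrogen). This is a further exchange of the group at the same place that was varied among compounds 1, 2 and 3, and none of those three exchanges moved the number beyond the scatter. The expectation for compound 4 in this assay is therefore no change at the digits printed from compound 3 to compound 4 (within the scatter), a step of no real size in either direction. On that basis compound 4 is estimated at 2600 nM, with a range from 1300 nM to 5200 nM.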

Compound 4, concentration for 50% growth inhibition: 12000 nM
For compound 4 the middle estimate is 4.6-fold (0.66 log units) below the measured one; the measured number lies above the stated range.
By their numbers in this assay, from the lowest: compounds 1, 3 and 2 (each within the scatter of the next); then compound 4.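

In this assay the position proves not to be indifferent to the group it carries, since 2-methoxyphenyl is set apart from all three earlier groups: the steps are a 4.6-fold higher number from compound 3 to compound 4 (0.66 log units; beyond the scatter), a 4.1-fold higher number from compound 2 to compound 4 (0.62 log units; beyond the scatter) and a 5.5-fold higher number from compound 1 to compound 4 (0.74 log units; beyond the scatter). Neither of the two plainest differences in the group accounts for this on its own, as compound 2 also carries a substituted phenyl group and compound 1 also carries oxygen in its group, yet both lie within the scatter of compound 3. Nothing available explains why the 2-methoxyphenyl group stands apart from the other three.

The compounds shown do not separate the methoxy group from the phenyl ring that carries it, so it remains open whether a plain phenyl, a 2-hydroxyphenyl or a 2-chlorophenyl group would stay with compounds 1, 2 and 3 or move with compound 4. They also leave open whether the same exchange would give a step of similar size on a longer chain joining the amine nitrogen to the sulfonamide.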